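The source may hold more compounds than are shown below. What is called first, only, known or untested is meant among the compounds shown, and "the series" means these compounds.

In a functional assay on PC-3M cells (Homo sapiens) for antiproliferative activity, read by microscopy, with a stated time of 24 h (a lower number here means a stronger inhibitor, a higher number a weaker inhibitor), compound 1 `COc1ccc(Cn2c(-c3ccccc3)c(-c3ccccc3)c3c(=N)n(C4CCOCC4)cnc32)cc1` gives 170 nM; 174 nM (2 entries) and compound 2 `COc1ccc(Cn2c(-c3ccccc3)c(-c3ccccc3)c3c(=N)n([C@H]4CC[C@H](O)CC4)cnc32)cc1` gives 160 nM; 158 nM (2 entries), two values within the scatter of each other. Compound 3 `COc1ccc(-c2c(-c3ccc(OC)cc3)n(Cc3ccccc3)c3ncn([C@H]4CC[C@H](O)CC4)c(=N)c23)cc1` gives > 20000 nM in this assay, which is a limit and not a number, and its further entries give no single number either. Compound 4 `COc1ccc(-c2c(-c3ccc(OC)cc3)n(Cc3ccccc3)c3ncn(CC4CCOC4)c(=N)c23)cc1` keeps the rest of compound 3 and carries (oxolan-3-yl)methyl in place of 4-hydroxycyclohexyl on an aromatic nitrogen. Going by the values given here, no measured step isolates that exchange, so the expectation rests on compound 3 and its limit of > 20000 nM. In this assay no step beyond the scatter is expected, and the estimated step is a number no higher from compound 3 to compound 4 (the limit leaves the size open). The estimate for compound 4 is 20000 nM, with an expected range of 4000 nM to 40000 nM.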

Compound 4, half-maximal inhibitory concentration: > 20000 nM
Compound 4: only a limit was reported; the forecaster's own chance of this, stated with the estimate: 70%; the middle value lies on the limit itself.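

Going by these compounds alone, compound 3 and compound 4 both stand only as limits in this assay, so no step between them can be read. The compounds shown leave open what (oxolan-3-yl)methyl in place of 4-hydroxycyclohexyl does to antiproliferative activity.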